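This account rests on a few compounds, and the source may have more. Where it says the series, first, only, none or still open, it means among the compounds named here.

Working notes on the series.

Two compounds of the shared core have a number in an assay on BTI cells for inhibition of Amine oxidase [flavin-containing] B (Homo sapiens), read by fluorescence and Amplex Red, with a stated time of 15 min; a higher number here means a weaker inhibitor, a lower number a stronger inhibitor. Compound 1 `CC(=O)N1N=C(c2ccc(C)cc2)OC1c1ccc(Cl)c(Cl)c1` gives 19.4 nM in this assay. Going by the values given here, compound 2 `CC(=O)N1N=C(c2ccc(Cl)cc2)OC1c1ccc(Cl)c(Cl)c1` gives 627 nM in this assay, the highest of the two numbers so far, and its nearest neighbour is compound 1; the single step between them, a 32-fold higher number from compound 1 to compound 2 (1.51 log units; beyond the scatter), is the only step yet measured in this assay.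

Compound 3 `CC(=O)N1N=C(c2ccc([N+](=O)[O-])cc2)OC1c1ccc(Cl)c(Cl)c1` is the next member, not yet measured. It differs from compound 2 by nitro in place of chloro on an aromatic carbon, on an aromatic carbon of a six-membered aromatic ring of carbon only, para to a large group.

Among the compounds with values here, no measured step swaps chloro for nitro, so nothing bears on this change directly; the step of a 32-fold higher number from compound 1 to compound 2 (1.51 log units; beyond the scatter) shows only that a change at this position can move the number a great deal, and gives no direction for the nitro group. Compound 3 is therefore expected to stay close to compound 2, with a wide range, estimated at 1000 nM in this assay (200 nM to 5000 nM), that is an expected step of a 1.6-fold higher number from compound 2 to compound 3 (0.20 log units; within the scatter).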

Compound 3, half-maximal inhibitory concentration: 9.46 nM
Estimate against measurement, compound 3: 110-fold (2.02 log units) above, outside the stated range (below it).
By their numbers in this assay, from the lowest: compound 3; then compound 1; then compound 2.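

In this assay the swap of chloro for nitro gives a 66-fold lower number from compound 2 to compound 3 (1.82 log units; beyond the scatter) on this aromatic carbon, para to a large group, so the position can move the number strongly in both directions and the high number of the chloro compound is not a general feature of changes here. Nitro also stands apart from methyl, with a 2.1-fold lower number from compound 1 to compound 3 (0.31 log units; beyond the scatter) as a modest step that is still beyond the scatter, which leaves compound 3 with the lowest number of the three and chloro as the one group of the three far from the others. Nothing available on these compounds explains why chloro differs so much from both methyl and nitro at this position.

The compounds shown leave open whether the low numbers extend to other groups on this carbon, such as a nitrile, a methoxy group or an amine, and whether fluoro or bromo would sit with chloro at the high end. They also leave open whether the same order of nitro, methyl and chloro holds when the two chloro groups on the other aromatic ring or the acetyl group are replaced.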